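Acetyl on the Core Amine of a Urea Analogue

A few compounds are considered here, and "the series" means these few. Any claim that something is new, unique, unknown or untested is made for them only; others in the source may bear on it.

Of the compounds shown here, two have been measured so far in a functional assay on SK-MEL-5 cells (Homo sapiens) for antiproliferative activity, read by sulforhodamine B assay, with a stated time of 48 h; a higher number here means a weaker inhibitor, a lower number a stronger inhibitor. Compound 1 `CC(=O)Nc1cccc2c(-c3cccc(NC(=O)c4ccc(Cl)c(C(F)(F)F)c4)c3)ccnc12` gives 1700 nM in this assay. Compound 2 `Nc1cccc2c(-c3cccc(NC(=O)Nc4cc(C(F)(F)F)cc(C(F)(F)F)c4)c3)ccnc12` gives 8700 nM in this assay, the higher of the two numbers and therefore the weaker inhibitor, by a gap that lies beyond the usual scatter. Compound 1 differs from compound 2 in more than one place, so its value offers only a rough bearing and not a direct step.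

Compound 3 `CC(=O)Nc1cccc2c(-c3cccc(NC(=O)Nc4cc(C(F)(F)F)cc(C(F)(F)F)c4)c3)ccnc12` is compound 2 with one change: acetyl in place of hydrogen on a nitrogen on an aromatic ring. Within the data shown here, the data hold no measured pair that isolates this change, so the size of its effect can only be guessed. Since compound 1, the stronger of the two measured compounds, gives 1700 nM, a move toward lower numbers seems somewhat more likely than the reverse, yet the step from compound 2 to compound 3 is expected to be modest, a 1.9-fold lower number from compound 2 to compound 3 (0.29 log units; within the scatter), and may not exceed the scatter. Compound 3 is therefore expected to give about 4500 nM in this assay, in a range from 1500 nM to 13000 nM.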

Compound 3, half-maximal inhibitory concentration: 18600 nM
For compound 3 the middle estimate is 4.1-fold (0.62 log units) below the measured one; measured number outside the range, above it.
By their numbers in this assay, from the lowest: compound 1; then compound 2; then compound 3.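

In this assay, among these compounds, the change from amino to acetamido gives a 2.1-fold higher number from compound 2 to compound 3 (0.33 log units; beyond the scatter), a modest step but the first measured pair to isolate acetyl in place of hydrogen on a nitrogen on an aromatic ring. On this urea series, then, the acetyl group does not bring a stronger inhibitor: the compound with the free amino group is the stronger of the pair, and the position responds measurably to the change. Compound 1 also carries the acetamido group and gives 1700 nM, but it differs from compound 3 in more than one place, so its lower number cannot be credited to the acetyl group, and nothing available here explains the step in either case.

This single pair leaves open whether the same direction would hold with the amide linker and the chloro-substituted ring of compound 1, where no matching free amino compound is shown. It also leaves open how a methyl group or a longer acyl chain, such as propionyl, on this nitrogen would compare with hydrogen and acetyl.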